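Chloro on the Benzyl Ring: Ortho Instead of Meta

The source may report more compounds than this note shows. Statements on the series, on what has been measured and on what is new or still open speak of the compounds shown alone.

Compound 1 `COc1ccc(C2N=C(SCc3ccccc3)NC(C)=C2C(=O)Nc2ccc(Br)cc2)cc1` carries a plain benzyl group on sulfur. In a functional assay on the whole organism (artery, strain albino) with Rattus norvegicus as the target, with a stated time of 600 min, at a dose of 10 mg/kg by the oral route (on this read-out higher numbers stand for more inhibition at the one dose given (going by the name of the read-out) and lower numbers for less inhibition), compound 1 gives 11.3%. Compound 2 `COc1ccc(C2N=C(SCc3cccc(Cl)c3)NC(C)=C2C(=O)Nc2ccc(Br)cc2)cc1` adds a chlorine there, and in this assay compound 2 gives 32.8%, a change of a number 21.5 percentage points higher from compound 1 to compound 2 (beyond the scatter); the difference is chloro in place of hydrogen on an aromatic carbon, with the chlorine meta to a large group.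

Compound 3 `CC1=C(C(=O)Nc2ccc([N+](=O)[O-])cc2)C(c2cccc([N+](=O)[O-])c2)N=C(SCc2ccccc2)N1` has a different core, and the difference between the two cores is not broken down here. In this assay compound 3 gives 27.2%. Compound 4 `CC1=C(C(=O)Nc2ccc([N+](=O)[O-])cc2)C(c2cccc([N+](=O)[O-])c2)N=C(SCc2ccccc2Cl)N1` differs from compound 3 by chloro in place of hydrogen on an aromatic carbon, the same kind of change, but with the chlorine ortho to a large group.

Because compound 2 reached 32.8% after the meta chlorine, a rise is expected for compound 4 as well, though a smaller one, given the changed place and core, so compound 4 is expected to show a number 8.8 percentage points higher from compound 3 to compound 4 (within the scatter). Compound 4 is estimated to give 36% in this assay.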

Compound 4, a percentage reported as inhibition, in the whole organism at one dose (the size of the read-out at that dose, not a potency): 13.3%
Beside the measured number, compound 4's estimate is 22.7 percentage points above it; the whole stated range lies above it.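

In this assay, putting a chlorine on the benzyl ring gives a number 13.9 percentage points lower from compound 3 to compound 4 (beyond the scatter), and this step runs the opposite way to the one seen on the core of compound 1: the same change on two cores in this assay, a number 21.5 percentage points higher (beyond the scatter) from compound 1 to compound 2 and a number 13.9 percentage points lower (beyond the scatter) from compound 3 to compound 4, 35.4 percentage points apart, beyond the scatter of two such steps A rise from this change on one core therefore cannot be assumed on another core in this series. This does not show why the steps differ, since the chlorine in compound 4 sits ortho to a large group, compound 2 carries its chlorine elsewhere on the ring, and the cores differ too, so these factors cannot be separated.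

On these data alone, it remains open how chlorine at one shared place would behave on both cores. As far as these compounds go, it is also open whether an amine or a carboxylic acid on the benzyl ring would shift the number alike on each core.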